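The compounds below may be only part of what the source reports. "The series", "measured", "known", "first", "only" and "open" are said of these compounds alone.

Working notes on the series. Compound 1 `Clc1ccc(C2CC(c3ccc(N4CCCCC4)cc3)=NN2c2nc(-c3ccccc3)cs2)cc1` carries hydrogen at the aromatic carbon that the later compounds vary; in a functional assay on A549 cells (Homo sapiens) for antiproliferative activity, read by MTT assay, with a stated time of 72 h (a higher number here means a weaker inhibitor, a lower number a stronger inhibitor), compound 1 gives 64200 nM. For the measured compounds named here, compound 2 `Clc1ccc(-c2csc(N3N=C(c4ccc(N5CCCCC5)cc4)CC3c3ccc(Cl)cc3)n2)cc1` has chloro on that aromatic carbon, and in this assay compound 2 gives 46400 nM, the second highest of the three numbers so far; the step of a 1.4-fold lower number from compound 1 to compound 2 (0.14 log units; within the scatter) is within the scatter. Compound 3 `N#Cc1ccc(-c2csc(N3N=C(c4ccc(N5CCCCC5)cc4)CC3c3ccc(Cl)cc3)n2)cc1` has cyano on the same aromatic carbon, and in this assay compound 3 gives 11200 nM; the steps of a 5.7-fold lower number from compound 1 to compound 3 (0.76 log units; beyond the scatter) and a 4.1-fold lower number from compound 2 to compound 3 (0.62 log units; beyond the scatter) are both modest but beyond the scatter.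

Compound 4 `Cc1ccc(-c2csc(N3N=C(c4ccc(N5CCCCC5)cc4)CC3c3ccc(Cl)cc3)n2)cc1` is not yet measured. Its change from compound 2 is methyl in place of chloro on an aromatic carbon. Going by the values given here, no measured step swaps chloro for methyl, so the expectation rests on the two steps at this aromatic carbon: hydrogen to chloro, a 1.4-fold lower number from compound 1 to compound 2 (0.14 log units; within the scatter), stayed within the scatter, while chloro to cyano, a 4.1-fold lower number from compound 2 to compound 3 (0.62 log units; beyond the scatter), lowered the number modestly. Only the cyano change moved the number; the expected step of a 1.0-fold lower number from compound 2 to compound 4 (0.01 log units; within the scatter) in this assay is therefore none beyond the scatter. For compound 4 in this assay the estimate is 45000 nM, with a range from 20000 nM to 100000 nM.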

Compound 4, half-maximal inhibitory concentration: > 100000 nM
Compound 4: a limit, no number (the forecaster's own chance of this, stated with the estimate: 10%); middle value at least 2.2-fold (0.34 log units) away from the limit.
By their numbers in this assay, from the lowest: compound 3; then compounds 2 and 1 (each within the scatter of the next). At a limit, above all of these: compound 4.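

The reading for compound 4 is a limit of the assay and not a number: the limit of > 100000 nM in this assay, at which 1 of the 4 values shown sits. This position therefore responds to more than cyano: in this assay, methyl in place of chloro gives an at least 2.1-fold higher number from compound 2 to compound 4 (0.33 log units; beyond the scatter), a shift opposite in direction to the one seen with cyano, so exchanging one heavy atom for another on the 4-chlorophenyl group is enough to produce a change beyond the scatter. For the compounds shown here, the span at this carbon is also wider than the earlier compounds showed, with an at least 8.9-fold higher number from compound 3 to compound 4 (0.95 log units; beyond the scatter) as the gap between cyano and methyl, whereas an at least 1.5-fold higher number from compound 1 to compound 4 (0.19 log units; that floor lies within the scatter) has a floor within the scatter, so these values do not separate methyl from hydrogen.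

On these data alone, how far compound 4 lies past its limit remains open, so the full size of all three steps is unknown. Also open, as far as these compounds go, is where an amine, a carboxylic acid, a methoxy group or a longer chain such as propyl at this same carbon would fall relative to the cyano of compound 3 and the methyl of compound 4.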